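This account rests on a few compounds, and the source may have more. Where it says the series, first, only, none or still open, it means among the compounds named here.

Measured compounds in an ADME assay on Raji cells (Homo sapiens) for cytotoxicity, read by CellTiter-Glo and resazurin assay, with a stated time of 72 h; a higher number here means that more compound is needed for the effect, a lower number that less compound is needed:
Compound 1 `CCOC(=O)CCCCCOc1cccc(CN(C(=O)c2ccccc2)C(C)C)c1` gives > 26000 nM, a limit of the assay rather than a number.
Compound 2 `CCOC(=O)CCCCCOc1cccc(CN(C(=O)c2ccc(-c3cccc(C(C)=O)c3)cc2)C(C)C)c1` gives > 26000 nM, again a limit.
Compound 3 `CCOC(=O)CCCCCOc1cccc(CN(C(=O)c2ccc(-c3cccc(-c4nnc(C)o4)c3)cc2)C(C)C)c1` gives > 26000 nM, also a limit.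

Compound 3 therefore stands where every measured member of the series stands: at the limit of > 26000 nM in this assay, at which 3 of the 3 values shown sit. Among the measured compounds shown here, no compound has a readable number, so none can be ranked against another.

The change under consideration leads from compound 3 to compound 4 `CCOC(=O)CCCCCOc1cccc(CN(C(=O)c2ccc(-c3cccc(OCC)c3)cc2)C(C)C)c1`. It reads (ethoxy in place of 5-methyl-1,3,4-oxadiazol-2-yl on an aromatic carbon).

For the measured compounds named here, three measured steps touch the same region of the structure, the six-membered aromatic ring of carbon only that carries the varied group: a step that the two limits leave unreadable from compound 1 to compound 2, a step that the two limits leave unreadable from compound 1 to compound 3 and a step that the two limits leave unreadable from compound 2 to compound 3. Each lies between two limits, so none of them yields a size or a direction. Replacing the 5-methyl-1,3,4-oxadiazol-2-yl by acetyl, or removing the whole 3-substituted phenyl, left the read-out at the limit in every case.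

For compound 4 the expectation is accordingly that this assay again returns a limit and no number, the step from compound 3 being estimated as a step that the limit leaves unreadable from compound 3 to compound 4. Compound 4 is estimated at 40000 nM, with a range from 20000 nM to 120000 nM, the lower end sitting near the limit itself.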

Compound 4, half-maximal effective concentration: > 22300 nM
Compound 4 was reported as a limit; the forecaster's own chance of this, stated with the estimate: 85%; the middle value does not contradict the limit.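

In this assay compound 4 gives > 22300 nM, a limit and not a number. Its steps to compound 1, compound 2 and compound 3 all lie between limits and cannot be read. The compounds shown leave open whether any of these groups on the shared core gives a readable value in this assay, and how ethoxy, acetyl and 5-methyl-1,3,4-oxadiazol-2-yl would then compare.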